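A few compounds are considered here, and "the series" means these few. Any claim that something is new, unique, unknown or untested is made for them only; others in the source may bear on it.

Series notes. Compound 1 `O=C(C1CCC1)N1CC2CC(C1)N2` and compound 2 `O=C([C@H]1C[C@@H]1F)N1CC2CC(C1)N2` share one core and differ only in the group on the carbonyl carbon. Within the data shown here, in an assay on CHO cells for agonist activity at Neuronal acetylcholine receptor; alpha3/alpha6/beta2/beta3 (Homo sapiens), read by FLIPR and calcium flux (a lower number here means a smaller maximal response, a higher number a larger maximal response), compound 1 gives 80% and compound 2 gives 85%; the only step so far, a number 5 percentage points higher from compound 1 to compound 2 (within the scatter), places the two within the scatter of each other, so compound 2 stands level with compound 1. Compound 3 `C[C@H]1C[C@H]1C(=O)N1CC2CC(C1)N2` continues from compound 2 by the change (2-methylcyclopropyl in place of 2-fluorocyclopropyl on a carbonyl carbon), again on the same carbonyl carbon. Among the measured compounds shown here, the one measured step bearing on it was small, so no shift beyond the scatter is expected in this assay, and the expected step is a number 2 percentage points lower from compound 2 to compound 3 (within the scatter). Compound 3 is therefore estimated at 83%, with a range from 68% to 96%.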

Compound 3, largest response reached (Emax), in percent of the reference or control that the assay uses: 60%
Estimate against measurement, compound 3: 23 percentage points above; the whole stated range lies above it.
By their numbers in this assay, from the lowest: compound 3; then compounds 1 and 2 (each within the scatter of the next).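

In this assay, this carbonyl carbon proves sensitive to a small change: 2-methylcyclopropyl in place of 2-fluorocyclopropyl gives a number 25 percentage points lower from compound 2 to compound 3 (beyond the scatter), with the heavy-atom count and the three-membered ring unchanged. 2-Methylcyclopropyl in place of cyclobutyl gives a number 20 percentage points lower from compound 1 to compound 3 (beyond the scatter), so compound 3 separates beyond the scatter from both earlier compounds. No supporting data bear on why the response falls. The compounds shown leave open whether the other stereoisomers of 2-methylcyclopropyl behave alike. On these data alone, how a 2-ethylcyclopropyl or a 2-aminocyclopropyl would respond on the same carbonyl carbon also remains open.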